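This account rests on a few compounds, and the source may have more. Where it says the series, first, only, none or still open, it means among the compounds named here.

Measured compounds:
Compound 1, `COc1cc(NS(=O)(=O)c2ccc(N3CCNC3=O)cc2)cc(OC)c1OC`: 23 nM
Compound 2, `COc1cccc(NS(=O)(=O)c2ccc(N3CCNC3=O)cc2)c1`: 260 nM
Compound 3, `Cc1cccc(NS(=O)(=O)c2ccc(N3CCNC3=O)cc2)c1`: 200 nM

All three were tested in a functional assay on CCRF-CEM cells (Homo sapiens) for antiproliferative activity, read by sulforhodamine B assay, with a stated time of 48 h; a higher number here means a weaker inhibitor, a lower number a stronger inhibitor. Compound 2 stands highest of the three numbers; the smallest gap is a 1.3-fold lower number from compound 2 to compound 3 (0.11 log units; within the scatter), and the widest gap is to compound 1, whose number lies beyond the scatter below that of compound 2. Compound 4, `COc1cc(NS(=O)(=O)c2ccc(N3CCNC3=O)cc2)cc(OC)c1`, has not yet been measured. It differs from compound 2 in one place: methoxy in place of hydrogen on an aromatic carbon. For the measured compounds named here, the one recorded step, replacing methoxy with methyl, says little about adding a methoxy. The comparison with compound 1, which carries further methoxy groups and gives 23 nM, suggests that an added methoxy should lower the number. Compound 4 is therefore expected to show a 3.7-fold lower number from compound 2 to compound 4 (0.57 log units; beyond the scatter), landing near 70 nM with a range of 25 nM to 200 nM.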

Compound 4, half-maximal inhibitory concentration: 170 nM
Compound 4: the middle estimate sits 2.4-fold (0.39 log units) below what was measured; the measured number falls inside the stated range.
By their numbers in this assay, from the lowest: compound 1; then compounds 4, 3 and 2 (each within the scatter of the next).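

In this assay, methoxy in place of hydrogen on this aromatic carbon gives a 1.5-fold lower number from compound 2 to compound 4 (0.18 log units; within the scatter) and so brings no change that can be told apart from the scatter. The methoxy that separates compound 1 from compound 4 counts for much more, with a 7.4-fold higher number from compound 1 to compound 4 (0.87 log units; beyond the scatter) when it is lost. No measurement at hand accounts for this contrast between the two methoxy changes.

The compounds shown leave open whether an amine or a hydroxyl on the aromatic carbon of the methoxy added to compound 2 would differ from methoxy. They also leave open whether ethoxy in place of the methoxy lost from compound 1 would keep its number.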